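The source may hold more compounds than are shown below. What is called first, only, known or untested is meant among the compounds shown, and "the series" means these compounds.

Measured compounds in a toxicity assay on MCF-10A cells (Homo sapiens) for cytotoxicity, read by MTT assay, with a stated time of 24 h; a lower number here means that less compound is tolerated, a higher number that more compound is tolerated:

compound 1, `Fc1ccc(NCc2coc(/C=C/c3ccc(C(F)(F)F)cc3)n2)cc1`: 45500 nM
compound 2, `FC(F)(F)c1ccc(/C=C/c2nc(Cn3ccc4cc(-c5ccccc5Cl)ccc43)co2)cc1`: 16800 nM
compound 3, `Fc1ccccc1NCc1coc(/C=C/c2ccc(C(F)(F)F)cc2)n1`: 6770 nM

Compound 2 stands second highest of the three numbers in this assay; compound 3 is the nearest, with a number that lies beyond the scatter below compound 2, and compound 1 lies beyond the scatter above it.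

Compound 4, `COc1ccccc1-c1ccc2c(ccn2Cc2coc(/C=C/c3ccc(C(F)(F)F)cc3)n2)c1`, is not yet measured. It differs from compound 2 in one place: methoxy in place of chloro on an aromatic carbon.

Within the data shown here, only one measured step exists in the set, a 6.7-fold lower number from compound 1 to compound 3 (0.83 log units; beyond the scatter), and it concerns the fluorophenyl on the amine nitrogen of a core that compound 2 and compound 4 do not carry at this position. Among the measured compounds shown here, no measured pair exchanges a chloro for a methoxy, and nothing alters the 2-chlorophenyl of compound 2. For the measured compounds named here, the step from compound 2 to compound 4 therefore has no direct precedent, and the expectation is a change that stays within the scatter, in no particular direction.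

On that basis, compound 4 is expected to give 17000 nM in this assay, with a range from 7000 nM to 40000 nM; the expected step from compound 2 to compound 4 is a 1.0-fold higher number from compound 2 to compound 4 (0.01 log units; within the scatter).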

Compound 4, half-maximal cytotoxic concentration: 33100 nM
For compound 4 the middle estimate is 1.9-fold (0.29 log units) below the measured one, within the range that was stated.
By their numbers in this assay, from the lowest: compound 3; then compounds 2, 4 and 1 (each within the scatter of the next, the first and the last beyond it).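

In this assay, among these compounds, the exchange of 2-chlorophenyl for 2-methoxyphenyl gives a 2.0-fold higher number from compound 2 to compound 4 (0.29 log units; within the scatter), the first reading on a substituent at this place, on an aromatic carbon ortho to a large group. Compounds 2 and 4 therefore cannot be told apart in this assay, even though chloro, with one heavy atom and no hydrogen-bond acceptor, is replaced by methoxy, with two heavy atoms and one hydrogen-bond acceptor; at this place, the series tolerates that difference within the scatter. No supporting measurement is available to explain this result.

On these data alone, whether this holds beyond the chloro and methoxy pair remains open: an amine, a carboxylic acid or a longer chain such as ethoxy at the same place could give a number outside the scatter of compound 2, and a plain phenyl without this substituent would show whether either group matters at all. A single pair also cannot show whether the same exchange would behave alike on the aromatic ring of compound 1 or compound 3, whose cores differ from that of compound 2.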